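Replacing nonyl with tert-butoxy on compound 1

This account rests on a few compounds, and the source may have more. Where it says the series, first, only, none or still open, it means among the compounds named here.

Compound 1 (`CCCCCCCCCCCC/C=C\N(NC(=O)COC)C(=O)CCCCCCCCC`) gives > 110000 nM in a functional assay on K562 cells (Homo sapiens) for antiproliferative activity, read by resazurin assay, with a stated time of 72 h (a lower number here means a stronger inhibitor of growth, a higher number a weaker inhibitor of growth), as a limit of the assay and not as a number. Compound 2 (`CCCCCCCCCCCCCCN(NC(=O)COC)C(=O)CCCCCCCCC`) gives > 110000 nM as a limit as well. Compound 3 (`CCCCCCCCCCN(NC(=O)COC)C(=O)CCCCCCCCC`) gives 97300 nM as a measured number. Compound 1 thus sits at the limit of > 110000 nM in this assay, at which 2 of the 3 values shown sit, and has no number of its own.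

Compound 4 (`CCCCCCCCCCCC/C=C\N(NC(=O)COC)C(=O)OC(C)(C)C`) carries tert-butoxy in place of nonyl on a carbonyl carbon, and the count of that change is tert-butoxy in place of nonyl on a carbonyl carbon in full. Among the compounds with values here, the only measured step is an at least 1.1-fold lower number from compound 2 to compound 3 (0.05 log units; that floor lies within the scatter) on the chain at nitrogen, and no measured step touches the group on the carbonyl carbon. Compound 3 at 97300 nM shows a number with less chain, so only a modest move toward a lower number is expected. The expected size is an estimated at least 1.4-fold lower number from compound 1 to compound 4 (0.16 log units; that floor lies within the scatter) in this assay and no more. For compound 4 the estimate is 75000 nM with an expected range of 25000 nM to 130000 nM and a real chance of another limit.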

Compound 4, concentration for 50% growth inhibition: 28300 nM
Compound 4: the middle estimate sits 2.7-fold (0.42 log units) above what was measured, and the stated range covers the measured number.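

In this assay, the group on the carbonyl carbon proves to be a position that moves the read-out: the change to tert-butoxy gives an at least 3.8-fold lower number from compound 1 to compound 4 (0.58 log units; beyond the scatter). Within the data shown here, the earlier step on the chain at nitrogen, an at least 1.1-fold lower number from compound 2 to compound 3 (0.05 log units; that floor lies within the scatter), gave no reading beyond the scatter, so this is the first step that clears it. Its size is only a floor, because compound 1 carries a limit and no number of its own: the limit of > 110000 nM in this assay, at which 2 of the 4 values shown sit.

The compounds shown leave open whether the step follows the loss of nonyl or the entry of tert-butoxy; a propyl chain or a methoxy group on the same carbonyl carbon would separate the two. Also open, going by these compounds, is whether tert-butoxy gives a similar step with the saturated chains of compound 2 and compound 3 at nitrogen.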